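This account rests on a few compounds, and the source may have more. Where it says the series, first, only, none or still open, it means among the compounds named here.

Measured compounds:
- compound 1 `CN(C)CCNc1ccnc2cc(OCc3ccc(F)cc3)ccc12`: 790 nM
- compound 2 `Fc1ccc(COc2ccc3c(Cl)ccnc3c2)cc1`: 3010 nM

In a functional assay on HepG2 cells (Homo sapiens) for cytotoxicity, read by MTT assay, with a stated time of 48 h (a higher number here means a weaker inhibitor, a lower number a stronger inhibitor), compound 1 gives 790 nM, the lowest of the two numbers measured. For the measured compounds named here, in the same test compound 2 gives 3010 nM, and the only measured step, a 3.8-fold higher number from compound 1 to compound 2 (0.58 log units; beyond the scatter), comes from swapping the (2-(dimethylamino)ethyl)amino group for chloro on an aromatic carbon of the shared core.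

Compound 3 `CN(C)CCNc1ccnc2cc(OCc3ccccc3)ccc12` has not yet been measured. It differs from compound 1 in one place only: hydrogen in place of fluoro on an aromatic carbon. Going by the values given here, the change sits on the six-membered aromatic ring of carbon only, away from the part of compound 1 that was altered in the single measured step, so that step offers no direct guidance on what removing the fluoro will do. With nothing to suggest otherwise, the expected step of a 1.1-fold higher number from compound 1 to compound 3 (0.03 log units; within the scatter) lies within the usual scatter, in no particular direction. Compound 3 is therefore estimated at 850 nM in this assay, with a likely range from 400 nM to 1800 nM.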

Compound 3, half-maximal inhibitory concentration: 3120 nM
Beside the measured number, compound 3's estimate is 3.7-fold (0.56 log units) below it; measured number outside the range, above it.
By their numbers in this assay, from the lowest: compound 1; then compounds 2 and 3 (each within the scatter of the next).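

In this assay the step of a 3.9-fold higher number from compound 1 to compound 3 (0.60 log units; beyond the scatter) shows that the fluoro of the 4-fluorobenzyl group is not a silent passenger: losing this one heavy atom, on an aromatic carbon para to a large group, moves the number beyond the scatter. For the compounds shown here, the only earlier step concerned the (2-(dimethylamino)ethyl)amino group, so this is the first sign that the 4-fluorobenzyl part of compound 1 also counts in this test, and both single changes measured from compound 1 give a higher number. No measurement at hand says why this one atom matters in these cells.

From the compounds shown here alone, it remains open whether fluoro is unusual here or whether chloro, methoxy or a nitrile on that same carbon would keep the number close to that of compound 1. Also open, going by these compounds, is whether the fluoro would count in the same way alongside a different side chain on the shared core, such as a longer chain ending in a morpholine.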